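Removing the benzyl group from the ring oxygen in a second series

The compounds below may be only part of what the source reports. "The series", "measured", "known", "first", "only" and "open" are said of these compounds alone.

Compound 1 `Cc1c(OCc2ccccc2)c(=O)ccn1CCCCCCNc1ccnc2cc(Cl)ccc12` and compound 2 `Cc1c(O)c(=O)ccn1CCCCCCNc1ccnc2cc(Cl)ccc12` share a core and differ only in one place: hydrogen in place of benzyl on an oxygen on an aromatic ring. In an ADME assay on KB cells (Homo sapiens) for cytotoxicity, read by resazurin assay, with a stated time of 72 h (a lower number here means a stronger inhibitor, a higher number a weaker inhibitor), compound 1 gives 158000 nM, while compound 2 gives 4000 nM, so that a 40-fold lower number from compound 1 to compound 2 (1.60 log units; beyond the scatter). Compound 3 `CCc1c(OCc2ccccc2)c(=O)ccn1CCCNc1ccnc2cc(Cl)ccc12` belongs to a second series; the difference between its core and the core of compound 1 is not broken down here. In this assay compound 3 gives 15000 nM, which places it between the two compounds of the first series. Compound 4 `CCc1c(O)c(=O)ccn1CCCNc1ccnc2cc(Cl)ccc12` has not yet been measured. It stands to compound 3 as compound 2 stands to compound 1, with the same change at the same place: hydrogen in place of benzyl on an oxygen on an aromatic ring. Because compound 1 and compound 2 showed a 40-fold lower number from compound 1 to compound 2 (1.60 log units; beyond the scatter), a step of similar direction is expected for compound 4, though the second core may temper its size. The estimated step is a 25-fold lower number from compound 3 to compound 4 (1.40 log units; beyond the scatter). For compound 4 in this assay the estimate is 600 nM, with a likely range from 150 nM to 2500 nM.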

Compound 4, half-maximal inhibitory concentration: 55000 nM
Beside the measured number, compound 4's estimate is 92-fold (1.96 log units) below it; measured number above the stated range.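

On the core of compound 3, the change from benzyloxy to hydroxy gives a 3.7-fold higher number from compound 3 to compound 4 (0.56 log units; beyond the scatter) in this assay, which reverses the direction seen on the core of compound 1. Set side by side, the two steps do not agree: the same change on two cores in this assay, a 40-fold lower number (1.60 log units; beyond the scatter) from compound 1 to compound 2 and a 3.7-fold higher number (0.56 log units; beyond the scatter) from compound 3 to compound 4, 140-fold (2.16 log units) apart, beyond the scatter of two such steps This shows that the effect of the change did not carry from one core to the other in these two pairs, but it does not show which difference between the cores is responsible, and two pairs give no rule for any further core.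

The compounds shown leave open whether the reversal follows the length of the chain or the methyl and ethyl groups on the core, which change together here. They also leave open how a methoxy group or an amine in place of the benzyloxy group would read on either core.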